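The compounds below may be only part of what the source reports. "The series", "measured", "known", "first", "only" and "open" are said of these compounds alone.

Working notes on the indole vinyl sulfone series.

For the measured compounds named here, compound 2 `COc1ccc2[nH]c(-c3ccccc3)c(/C=C(\C#N)S(=O)(=O)c3ccccc3)c2c1` gives the higher of the two numbers so far in a functional assay on MDA-MB-231 cells (Homo sapiens) for inhibition, read by sulforhodamine B assay, with a stated time of 48 h; on this read-out higher numbers stand for weaker inhibition of growth and lower numbers for stronger inhibition of growth: compound 2 gives 7500 nM. Its nearest neighbour is compound 1 `CC(=O)/C(=C\c1c(-c2ccccc2)[nH]c2ccccc12)S(=O)(=O)c1ccccc1`, which differs from it in two places and gives 1700 nM in this assay, a gap that lies beyond the scatter; since compound 1 and compound 2 differ in more than one place, their two values do not isolate either change.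

Compound 3 `N#C/C(=C\c1c(-c2ccccc2)[nH]c2ccccc12)S(=O)(=O)c1ccccc1` is the next member. It differs from compound 2 only in one respect: hydrogen in place of methoxy on an aromatic carbon. Going by the values given here, no measured pair isolates this change, so its direction is not fixed by the data. A modest move toward lower numbers is expected, with the estimated step of a 2.1-fold lower number from compound 2 to compound 3 (0.33 log units; beyond the scatter) in this assay. Compound 3 is therefore estimated at 3500 nM in this assay, with an expected range from 1200 nM to 10000 nM.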

Compound 3, concentration for 50% growth inhibition: 3800 nM
Estimate against measurement, compound 3: 1.1-fold (0.04 log units) below; the range from low to high includes it.
By their numbers in this assay, from the lowest: compound 1; then compounds 3 and 2 (each within the scatter of the next).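

In this assay hydrogen in place of methoxy on the aromatic carbon now gives a single-place reading (a 2.0-fold lower number from compound 2 to compound 3 (0.30 log units; within the scatter)) and shows no separation between these two groups at this position. Cyano in place of acetyl on the double-bonded chain carbon is the only single-place change shown that goes beyond the scatter (a 2.2-fold higher number from compound 1 to compound 3 (0.35 log units; beyond the scatter)) and the lower number belongs to compound 1, which carries the acetyl group. Nothing at hand bears on why either step has its size.

Each step rests on a single pair, so neither can yet be taken as holding with other groups elsewhere on the shared core. Going by these compounds, how an amine on the aromatic carbon or a carboxylic acid on the double-bonded chain carbon would read remains open.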